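Phenyl for butyl on the benzimidazole side chain

The compounds below may be only part of what the source reports. "The series", "measured", "known", "first", "only" and "open" are said of these compounds alone.

Measured compounds:
compound 1, `CCCCCCCc1nc2ccccc2[nH]1` — 4.43
compound 2, `CCCCCCCCc1nc2ccccc2[nH]1` — 4.93
compound 3, `c1ccc(CCCc2nc3ccccc3[nH]2)cc1` — 4.46

Three compounds share a core and differ only in the chain attached to it. In a physicochemical assay for lipophilicity (on this read-out higher numbers stand for higher lipophilicity and lower numbers for lower lipophilicity), compound 1 gives 4.43, compound 2 gives 4.93 and compound 3 gives 4.46. The two chain-extended compounds differ by one methyl: methyl in place of hydrogen on a saturated chain carbon, seven bonds along the chain from an aromatic carbon. That change gives a number 0.50 log units higher from compound 1 to compound 2 (beyond the scatter). Compound 2 stands highest of the three, with a number 0.47 log units lower from compound 2 to compound 3 (beyond the scatter).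

The change from compound 1 to compound 3 is phenyl in place of butyl on a saturated chain carbon, three bonds along the chain from an aromatic carbon. In this assay this gives a number 0.03 log units higher from compound 1 to compound 3 (within the scatter). Compound 4, `c1ccc(CCCCc2nc3ccccc3[nH]2)cc1`, has not yet been measured. It arises from compound 2 by phenyl in place of butyl on a saturated chain carbon, four bonds along the chain from an aromatic carbon. For the measured compounds named here, this is the same kind of change as the one from compound 1 to compound 3, although the place differs: in the first case the group sits three bonds along the chain from an aromatic carbon, in the second four bonds along the chain from an aromatic carbon.

Since compound 3 moved only by a number 0.03 log units higher from compound 1 to compound 3 (within the scatter), the expected step for compound 4 is a number 0.02 log units higher from compound 2 to compound 4 (within the scatter), resting on that single earlier step. Compound 4 is therefore estimated at 4.95 in this assay, with a range from 4.6 to 5.3.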

Compound 4, partition coefficient: 4.96
Estimate against measurement, compound 4: 0.01 log units below, and the stated range covers the measured number.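

In this assay, phenyl in place of butyl, here on a saturated chain carbon four bonds along the chain from an aromatic carbon, gives a number 0.03 log units higher from compound 2 to compound 4 (within the scatter) and so stays within the scatter, as the same kind of change did when it gave a number 0.03 log units higher from compound 1 to compound 3 (within the scatter) on the shorter chain. Compound 4 also stands apart from compound 1, with a number 0.53 log units higher from compound 1 to compound 4 (beyond the scatter) beyond the scatter, so the swap of butyl for phenyl leaves in place the separation that compound 2 already had from compound 1 through a number 0.50 log units higher from compound 1 to compound 2 (beyond the scatter) on the same read-out. This shows the change carrying over in just two pairs of compounds, at two places on the chain and in one assay, so it does not establish that it would carry to a core of another kind, and nothing measured here speaks to why butyl and phenyl read alike.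

The compounds shown leave open whether the match holds for chains longer than those of compound 2 and compound 4. They also leave open what happens when an amine or a carboxylic acid stands on the chain in place of the phenyl.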